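Compound 3 loses its methoxy

The source may hold more compounds than are shown below. What is called first, only, known or untested is meant among the compounds shown, and "the series" means these compounds.

Compounds measured in a functional assay on DU-145 cells (Homo sapiens) for antiproliferative activity, read by MTT assay, with a stated time of 48 h; on this read-out higher numbers stand for weaker inhibition and lower numbers for stronger inhibition:
- Compound 1 `C/C(=C\CC/C(C)=C/CC[C@@H]1[C@@]2(C)CCC(=O)C(C)(C)[C@H]2CC[C@@]1(C)O)CC/C=C(\C)C(=O)OCc1cn(-c2ccc([N+](=O)[O-])cc2)nn1`: > 150000 nM, a limit
- Compound 2 `C#CCOC(=O)/C(C)=C/CC/C(C)=C/CC/C(C)=C/CC[C@@H]1[C@@]2(C)CCC(=O)C(C)(C)[C@H]2CC[C@@]1(C)O`: 46100 nM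
- Compound 3 `COc1ccc(-n2cc(COC(=O)/C(C)=C/CC/C(C)=C/CC/C(C)=C/CC[C@@H]3[C@@]4(C)CCC(=O)C(C)(C)[C@H]4CC[C@@]3(C)O)nn2)cc1`: 135000 nM

Compound 3 gives 135000 nM, the higher of the two exact numbers, while compound 2 gives 46100 nM. Compound 1 is known only as a limit, > 150000 nM.

Compound 4 `C/C(=C\CC/C(C)=C/CC[C@@H]1[C@@]2(C)CCC(=O)C(C)(C)[C@H]2CC[C@@]1(C)O)CC/C=C(\C)C(=O)OCc1cn(-c2ccccc2)nn1` has hydrogen in place of methoxy on an aromatic carbon, para to a large group (hydrogen in place of methoxy on an aromatic carbon). Within the data shown here, one measured step bears on this change, an at least 1.1-fold lower number from compound 1 to compound 3 (0.04 log units; that floor lies within the scatter), with methoxy in place of nitro. It gives no sign of a large effect at that place, so no shift beyond the scatter is expected in this assay. The expected step is a 1.0-fold lower number from compound 3 to compound 4 (0.02 log units; within the scatter). A reading at the limit of > 150000 nM in this assay, at which 1 of the 3 values shown sits, remains possible. Compound 4 is estimated at 130000 nM, with an expected range of 70000 nM to 240000 nM.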

Compound 4, half-maximal inhibitory concentration: 95500 nM
Compound 4: middle estimate off by 1.4-fold (0.13 log units), on the high side; low and high end bracket the measured number.
By their numbers in this assay, from the lowest: compound 2; then compounds 4 and 3 (each within the scatter of the next). At a limit, above all of these: compound 1.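

In this assay, hydrogen in place of methoxy gives a 1.4-fold lower number from compound 3 to compound 4 (0.15 log units; within the scatter), so this pair shows no change beyond the scatter at this place. Hydrogen in place of nitro gives an at least 1.5-fold lower number from compound 1 to compound 4 (0.19 log units; that floor lies within the scatter), which is only a floor, as compound 1 is a limit: the limit of > 150000 nM in this assay, at which 1 of the 4 values shown sits. The 1-phenyl-1H-1,2,3-triazol-4-yl group in place of ethynyl gives a 2.1-fold higher number from compound 2 to compound 4 (0.32 log units; beyond the scatter), so a modest step beyond the scatter is seen even with no substituent on the phenyl. Going by these compounds, what an amine or a carboxylic acid on this aromatic carbon would do remains open.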